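A Fluorine Added to a Phenyl Ring

The source may hold more compounds than are shown below. What is called first, only, known or untested is meant among the compounds shown, and "the series" means these compounds.

Two measured compounds share one core and differ only at one end of it. Compound 1 `Nc1ccccc1NC(=O)c1ccc(CSC(=S)N2CCN(C(c3ccccc3)c3ccccc3)CC2)cc1` and compound 2 `Nc1ccccc1NC(=O)c1ccc(CSC(=S)N2CCN(c3ccccc3)CC2)cc1` were both tested in a functional assay on HeLa cells (Homo sapiens) for antiproliferative activity, read by CCK-8 assay, with a stated time of 72 h, tested at 2 uM; on this read-out higher numbers stand for a stronger effect at the one concentration tested and lower numbers for a weaker effect. There compound 1 gives 8%, and compound 2 gives 62.2%. On these two numbers compound 2 stands highest; its nearest neighbour, compound 1, lies far below it, beyond the usual scatter. Compound 3 `Nc1ccccc1NC(=O)c1ccc(CSC(=S)N2CCN(c3ccc(F)cc3)CC2)cc1` is the next step from compound 2: fluoro in place of hydrogen on an aromatic carbon. For the measured compounds named here, no pair of measured compounds shows what such a change does here, so the expectation rests on compound 2 alone. In this assay a small step is expected, either none beyond the scatter or slightly downward. Compound 3 is therefore expected to give 58%, with a range from 40% to 72%. The expected step of a number 4.2 percentage points lower from compound 2 to compound 3 (within the scatter) is modest.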

Compound 3, a percentage reported as inhibition, at one concentration (the size of the read-out at that concentration, not a potency): 60.8%
Compound 3: middle estimate off by 2.8 percentage points, on the low side; measured number inside the range.
By their numbers in this assay, from the lowest: compound 1; then compounds 3 and 2 (each within the scatter of the next).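

In this assay, for the compounds shown here, the change from phenyl to 4-fluorophenyl gives a number 1.4 percentage points lower from compound 2 to compound 3 (within the scatter) and is the first direct reading of a single change on this ring. The earlier compounds shown here could not provide this reading, as no measured pair differed in one place. On this aromatic carbon, para to a large group, fluoro in place of hydrogen therefore leaves the read-out within the usual scatter, and no measurement here offers an explanation for that.

This single pair leaves open whether the position accepts only a small atom or also a larger group, such as a methoxy group, an amine or a carboxylic acid. It also cannot show whether fluoro would behave the same way on another carbon of the ring, or how compound 2 and compound 3 compare across a range of concentrations.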